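Amino for chloro on the core of compound 1

This account rests on a few compounds, and the source may have more. Where it says the series, first, only, none or still open, it means among the compounds named here.

Going by the values given here, compound 1 `ClCc1cccc(Cn2cnc3c(Cl)nc(Cl)nc32)c1` gives 1820 nM in a functional assay on KM12 cells (Homo sapiens) for cytotoxicity, read by sulforhodamine B assay, with a stated time of 48 h (a lower number here means a stronger inhibitor of growth, a higher number a weaker inhibitor of growth), the lowest of the two numbers so far; its nearest neighbour, compound 2 `ClCc1cccc(Cn2cnc3nc(Cl)nc(Cl)c32)c1`, gives 16600 nM, a gap beyond the scatter. Compound 3 `Nc1nc(Cl)c2ncn(Cc3cccc(CCl)c3)c2n1` is not yet measured. It differs from compound 1 by amino in place of chloro on an aromatic carbon, on an aromatic carbon between two ring nitrogen atoms. Among the compounds with values here, no comparable step is measured, so only a modest change is expected, most likely a small loss, as a 1.6-fold higher number from compound 1 to compound 3 (0.22 log units; within the scatter). Compound 3 is therefore estimated at 3000 nM, within 800 nM to 12000 nM.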

Compound 3, concentration for 50% growth inhibition: 3310 nM
For compound 3 the middle estimate is 1.1-fold (0.04 log units) below the measured one, within the range that was stated.
By their numbers in this assay, from the lowest: compounds 1 and 3 (each within the scatter of the next); then compound 2.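

Amino in place of chloro on an aromatic carbon, between two ring nitrogen atoms, gives a 1.8-fold higher number from compound 1 to compound 3 (0.26 log units; within the scatter) in this assay. This position therefore accepts a hydrogen-bond donor in place of chloro, and compound 1 and compound 3 cannot be told apart in this assay. No measurement at hand bears on why the two compounds read alike.

On these data alone, it remains open whether a larger group at this carbon, such as a methylamino, a dimethylamino or a methoxy group, would read the same way. As far as these compounds go, the role of the chloromethyl group also remains open.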